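The compounds below may be only part of what the source reports. "The series", "measured", "known", "first", "only" and "open" are said of these compounds alone.

Compound 1, `CCCCCCCCCCn1cc(-c2nc3ccccc3cc2C)nn1`, is one of three compounds tested in a functional assay on U-937 cells (Homo sapiens) for cytotoxicity, read by MTT assay, with a stated time of 24 h; a higher number here means a weaker inhibitor, a lower number a stronger inhibitor. In this assay compound 1 gives > 100 ug/mL, which is a limit of the assay rather than a number. Compound 3, `CCc1cc2ccccc2nc1-c1cn(-c2ccc(F)cc2)nn1`, in this assay also gives > 100 ug/mL, again a limit. Compound 2, `Cc1cc2ccccc2nc1-c1cn(CCC(F)(F)C(F)(F)C(F)(F)C(F)(F)C(F)(F)C(F)(F)C(F)(F)C(F)(F)F)nn1`, gives 56.6 ug/mL in this assay. Two of the three values shown thus sit at the limit of > 100 ug/mL in this assay, at which 2 of the 3 values shown sit, and compound 1 is one of them. Compound 4, `CCCCCCCCCCn1cc(-c2nc3ccccc3cc2CCCCC)nn1`, has not yet been measured. It differs from compound 1 by butyl in place of hydrogen on a saturated chain carbon bound to an aromatic carbon. Among the compounds with values here, no step between two measured compounds covers a change of this kind, so there is no measured step to lean on, and the expectation rests on compound 1 alone. Compound 4 is expected to give 100 ug/mL in this assay, within a range from 40 ug/mL to 250 ug/mL. The step expected from compound 1 to compound 4 is a number no higher from compound 1 to compound 4 (the limit leaves the size open), which amounts to nothing clearly beyond the scatter, with a fair chance that the assay once more reports only a limit.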

Compound 4, half-maximal inhibitory concentration: 18.2 ug/mL
Compound 4: middle estimate off by 5.5-fold (0.74 log units), on the high side, and the stated range ends above it.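

The saturated chain carbon bound to an aromatic carbon turns out to be a place where a change counts: with methyl extended to pentyl and the rest of the molecule unchanged, this assay shows an at least 5.4-fold lower number from compound 1 to compound 4 (0.73 log units; beyond the scatter), a move towards stronger cytotoxicity. Compound 1 gives > 100 ug/mL, which is a limit of the assay and not a number. The true size of the step stays open because compound 1 sits at that limit: the limit of > 100 ug/mL in this assay, at which 2 of the 4 values shown sit.

A single step cannot show whether the number keeps falling as this chain grows, as it might with an octyl group, or whether pentyl is a special case. It also leaves open whether a chain ending in an amine or a carboxylic acid would give a similar result at this place.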